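Propoxy in place of cyclohexylamino on a carbonyl carbon

This account rests on a few compounds, and the source may have more. Where it says the series, first, only, none or still open, it means among the compounds named here.

Compound 2 `O=C(NC1CCCCC1)Oc1cccc(-c2cc(C(=O)NC3CCCCC3)nn2-c2ccccc2)c1` was tested in an assay on isolated protein for inhibition of Fatty-acid amide hydrolase 1 (Homo sapiens), read by fluorescence, with a stated time of 30 min (a lower number here means a stronger inhibitor, a higher number a weaker inhibitor), where compound 2 gives 288 nM. Among the compounds with values here, this is the lower of the two numbers recorded so far, but its only neighbour, compound 1 `CCOC(=O)c1cc(-c2cccc(OC(=O)NC3CCCCC3)c2)n(C)n1`, lies within the usual scatter of repeated measurements: in this assay compound 1 gives 303 nM, so the two cannot be ranked against each other.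

Compound 3 `CCCOC(=O)c1cc(-c2cccc(OC(=O)NC3CCCCC3)c2)n(-c2ccccc2)n1` has not yet been measured. It differs from compound 2 in one place: propoxy in place of cyclohexylamino on a carbonyl carbon. Within the data shown here, no pair of measured compounds isolates this exchange, so its effect is not known from the data at hand. Compound 1 and compound 2 differ in several places at once, yet their values sit within the scatter, and nothing recorded suggests that the group on that carbonyl carbon moves the number far. The step of a 1.0-fold higher number from compound 2 to compound 3 (0.02 log units; within the scatter) is therefore expected to stay within the scatter, in no clear direction. Compound 3 is estimated to give 300 nM in this assay, with a range from 120 nM to 750 nM.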

Compound 3, half-maximal inhibitory concentration: 27 nM
Beside the measured number, compound 3's estimate is 11-fold (1.05 log units) above it, and the stated range ends above it.
By their numbers in this assay, from the lowest: compound 3; then compounds 2 and 1 (each within the scatter of the next).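

In this assay, within the data shown here, the exchange of cyclohexylcarbamoyl for propoxycarbonyl is the first change at this carbonyl carbon that can be read on its own, and it gives an 11-fold lower number from compound 2 to compound 3 (1.03 log units; beyond the scatter) in a single step. The group on this carbonyl carbon therefore matters a great deal to the number in this assay, which the two earlier compounds, differing in several places at once, could not show. The step removes the six-membered non-aromatic ring and a hydrogen-bond donor and brings in an open chain with a hydrogen-bond acceptor, but nothing measured here says what lies behind the step or which of these differences counts.

The compounds shown leave open whether the step follows from the exchange of the amide nitrogen for the ester oxygen or from the exchange of the cyclohexyl ring for the propyl chain, since both change together here. A propylamino group or a cyclohexyloxy group on the same carbonyl carbon would separate the two, and a butoxy group or a free carboxylic acid would show how far the propoxy result extends.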